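The source may report more compounds than this note shows. Statements on the series, on what has been measured and on what is new or still open speak of the compounds shown alone.

Of the compounds shown here, two have been tested in a functional assay on A549 cells (Homo sapiens) for antiproliferative activity, read by sulforhodamine B assay, with a stated time of 72 h (on this read-out lower numbers stand for stronger inhibition of growth and higher numbers for weaker inhibition of growth), and neither gave a number. Compound 1, `Cc1cc(=O)oc2cc(SC3CCOC3=O)ccc12`, reached only the limit of the assay; in this assay compound 1 gives > 36100 nM, which is a limit and not a measured value. Compound 2, `CCc1cc(=O)c2ccc(OCc3ccccc3)c(C)c2o1`, likewise reached only a limit; in this assay compound 2 gives > 33900 nM, again a limit rather than a number. So compound 2 stands at the limit of > 33900 nM in this assay, at which 1 of the 2 values shown sits, and the one other value shown is also a limit, (the limit of > 36100 nM in this assay, at which 1 of the 2 values shown sits); no measured step between any two compounds exists here.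

Compound 3, `CCc1cc(=O)c2ccc(OCc3cccc(C(F)(F)F)c3)c(C)c2o1`, is not yet measured. It differs from compound 2 in one place: trifluoromethyl in place of hydrogen on an aromatic carbon. Since both values at hand are limits, no step is shown on which the size or direction of this change could rest. The expectation is that the step of an at least 1.1-fold lower number from compound 2 to compound 3 (0.05 log units; that floor lies within the scatter) stays within the scatter, with compound 3 most likely again at a limit. For compound 3 in this assay the estimate is 30000 nM, with a range from 8000 nM to 100000 nM.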

Compound 3, concentration for 50% growth inhibition: > 27600 nM
Compound 3: only a limit was reported (the forecaster's own chance of this, stated with the estimate: 70%); the middle value lies beyond the limit too.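

Compound 2 and compound 3 each gave only a limit in this assay, so the step of trifluoromethyl in place of hydrogen on an aromatic carbon cannot be read. With compound 1 also at a limit, the compounds shown leave open how strongly any of them inhibits growth, and whether any structural change alters that inhibition.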